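One Methoxy More: From Compound 2 to Compound 3

A few compounds are considered here, and "the series" means these few. Any claim that something is new, unique, unknown or untested is made for them only; others in the source may bear on it.

Compound 2 `COc1ccc(C(=O)/C=C/c2cc(-c3cc(OC)c(OC)c(OC)c3)n[nH]2)cc1` gives -47% in a functional assay on IGROV-1 cells (Homo sapiens) for cytotoxicity, read by sulforhodamine B assay, with a stated time of 48 h, tested at 10 uM (a lower number here means a stronger effect, a higher number a weaker effect of the compound at the concentration tested), the lowest of the two numbers recorded; its nearest neighbour, compound 1 `COc1cc(-c2cc(/C=C/C(=O)c3ccc(Cl)c(Cl)c3)[nH]n2)cc(OC)c1OC`, gives 75%. Compound 3 `COc1ccc(C(=O)/C=C/c2cc(-c3cc(OC)c(OC)c(OC)c3)n[nH]2)cc1OC` differs from compound 2 by methoxy in place of hydrogen on an aromatic carbon. Among the compounds with values here, the only measured step, a number 122 percentage points lower from compound 1 to compound 2 (beyond the scatter), also swaps the ring on a carbonyl carbon and is large, showing that this ring can move the read-out far, but it offers no direction for a methoxy added to a 4-methoxyphenyl ring. Compound 3 is therefore expected to move by a number 47 percentage points higher from compound 2 to compound 3 (beyond the scatter), with an estimate of 0% and a range from -60% to 70%.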

Compound 3, a percentage reported as activity, at one concentration (the size of the read-out at that concentration, not a potency): -84%
The estimate for compound 3 lay 84 percentage points above the measured number; measured number outside the range, below it.
By their numbers in this assay, from the lowest: compound 3; then compound 2; then compound 1.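

In this assay the ring on the carbonyl carbon still responds once it carries a 4-methoxyphenyl group: the change to 3,4-dimethoxyphenyl gives a number 37 percentage points lower from compound 2 to compound 3 (beyond the scatter) in the same direction as the earlier swap. Set against 3,4-dichlorophenyl, the 3,4-dimethoxyphenyl ring gives a number 159 percentage points lower from compound 1 to compound 3 (beyond the scatter) as the widest gap among these compounds. No measured evidence accounts for either step. From the compounds shown here alone, whether methoxy is needed at this place stays open, since a hydroxyl group, an amine or a longer ethoxy chain there could give a different number.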